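Chloro to 2-Hydroxyethoxy on a Cytotoxicity Series

The source may hold more compounds than are shown below. What is called first, only, known or untested is meant among the compounds shown, and "the series" means these compounds.

Measured compounds:
Compound 1 `COc1ccccc1Oc1c(N)nc(-c2cccc(F)c2)nc1Cl`: 21700 nM
Compound 2 `COc1ccccc1Oc1c(N)nc(-c2cccc(Cl)c2)nc1Cl`: 17900 nM

In a functional assay on B16 cells (Mus musculus) for cytotoxicity, read by CCK-8 assay, with a stated time of 24 h (on this read-out lower numbers stand for stronger inhibition and higher numbers for weaker inhibition), compound 1 gives 21700 nM, while compound 2 gives 17900 nM. Within the data shown here, the one measured step, a 1.2-fold lower number from compound 1 to compound 2 (0.08 log units; within the scatter), is a chloro-for-fluoro exchange and does not separate the two compounds. Compound 2 therefore stands at the lowest of two numbers shown, with compound 1 the nearest, though the gap lies within the scatter.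

Compound 3 `COc1ccccc1Oc1c(N)nc(-c2cccc(Cl)c2)nc1OCCO` differs from compound 2 as follows: 2-hydroxyethoxy in place of chloro on an aromatic carbon. Among the measured compounds shown here, no measured step bears directly on this change; the only step available concerns the 3-chlorophenyl group, not the chloro on the core, and it was within the scatter. Nothing in the data points to a strong shift in either direction. Compound 3 is expected to show a 1.5-fold higher number from compound 2 to compound 3 (0.16 log units; within the scatter), with a somewhat weaker result judged slightly more likely. The estimate for compound 3 is 26000 nM, in the range 8000 nM to 85000 nM.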

Compound 3, half-maximal inhibitory concentration: 5010 nM
Compound 3: middle estimate off by 5.2-fold (0.72 log units), on the high side, outside the stated range (below it).
By their numbers in this assay, from the lowest: compound 3; then compounds 2 and 1 (each within the scatter of the next).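

In this assay, replacing the chloro on the aromatic carbon next to the ring nitrogen with 2-hydroxyethoxy gives a 3.6-fold lower number from compound 2 to compound 3 (0.55 log units; beyond the scatter), a modest step but the only one shown that lies beyond the scatter. Among these compounds, the earlier pair differed only on the outer aryl ring, so this result is the first to show that the number responds to a change on the core itself, and that this position tolerates a larger group carrying a hydrogen-bond donor without loss of cytotoxicity. Nothing available explains why the number falls with this exchange.

The compounds shown leave open whether the terminal hydroxyl is needed, which a plain methoxy or ethoxy group at this position would test. They also leave open how a longer chain, a 2-aminoethoxy group or a carboxylic acid would read here.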